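Swapping propargyl for a methylbenzothiazolyl on the amine

The source may report more compounds than this note shows. Statements on the series, on what has been measured and on what is new or still open speak of the compounds shown alone.

In an ADME assay on A549 cells (Homo sapiens) for cytotoxicity, read by CellTiter-Glo (a lower number here means that less compound is tolerated, a higher number that more compound is tolerated), compound 1 `C#CCNCC(O)COc1ccc2c(C)c(Cc3ccccc3)c(=O)oc2c1` gives 95500 nM.
Compound 3 `Cc1c(Cc2ccccc2)c(=O)oc2cc(OCC(O)CNc3nccs3)ccc12` gives 93000 nM.
Compound 2 `Cc1c(Cc2ccccc2)c(=O)oc2cc(OCC(O)CNc3ccccc3)ccc12` reaches only a limit of the assay, > 100000 nM.

Compound 1 holds the higher of the two real numbers, yet the nearest value shows a 1.0-fold lower number from compound 1 to compound 3 (0.01 log units; within the scatter), so the two cannot be told apart. Compound 4 `Cc1ccc2nc(NCC(O)COc3ccc4c(C)c(Cc5ccccc5)c(=O)oc4c3)sc2c1` has not been measured; it differs from compound 1 by 6-methyl-1,3-benzothiazol-2-yl in place of propargyl on an amine nitrogen. Two measured steps alter the same amine nitrogen: an at least 1.0-fold higher number from compound 1 to compound 2 (0.01 log units; that floor lies within the scatter) and a 1.0-fold lower number from compound 1 to compound 3 (0.01 log units; within the scatter). Both stay inside the scatter, and one value among the three is a limit (the limit of > 100000 nM in this assay, at which 1 of the 3 values shown sits). A larger aromatic group on this nitrogen therefore gives no reason to expect a shift beyond the scatter, and compound 4 is estimated at 95000 nM, between 45000 nM and 200000 nM, meaning a 1.0-fold lower number from compound 1 to compound 4 (0.00 log units; within the scatter).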

Compound 4, half-maximal cytotoxic concentration: > 100000 nM
Compound 4: no number, only a limit; the forecaster's own chance of this, stated with the estimate: 40%; at least 1.0-fold (0.02 log units) between middle value and limit.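

In this assay, the amine nitrogen accepts 6-methyl-1,3-benzothiazol-2-yl, with 10 heavy atoms against the 3 of propargyl, and the change gives an at least 1.0-fold higher number from compound 1 to compound 4 (0.01 log units; that floor lies within the scatter). Extending the comparison from the smaller thiazole-bearing compound gives an at least 1.0-fold higher number from compound 3 to compound 4 (0.03 log units; that floor lies within the scatter), so even this much larger aromatic group produces no step beyond the scatter. The step between compound 2 and compound 4 cannot be read, and the top of the range now holds more of the values: the limit of > 100000 nM in this assay, at which 2 of the 4 values shown sit.

Still open, going by these compounds, is whether a carboxylic acid or a longer chain on this nitrogen would move the number beyond the scatter in this assay.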